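Swapping methyl for chloro on a fast-cleared compound

The source may hold more compounds than are shown below. What is called first, only, known or untested is meant among the compounds shown, and "the series" means these compounds.

Compound 1 (`Cc1cccc2c1nc(C)n2-c1ccc(C(=O)NC2CC2)s1`): 66 mL/min/kg
Compound 2 (`Cc1nc2cc(C(F)(F)F)ccc2n1-c1ccc(C(=O)NC2CC2)s1`): > 72 mL/min/kg
Compound 3 (`Cc1nc2ccc(C(F)(F)F)cc2n1-c1ccc(C(=O)NC2CC2)s1`): 68 mL/min/kg

Among the compounds with values here, in an in vitro ADME assay on microsomes from liver (Mus musculus) for pharmacokinetics, read by LC-MS (on this read-out higher numbers stand for fast clearance and lower numbers for slow clearance), compound 1 gives 66 mL/min/kg as one of only two true numbers. Compound 3 gives 68 mL/min/kg and this lies within the usual scatter of compound 1, so the two cannot be ranked. For compound 2 the entry > 72 mL/min/kg is a limit of the assay and not a number. All three compounds therefore show fast clearance. Within the data shown here, no two of them differ in one place only, so no measured step shows how large a single swap tends to be.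

Compound 4 (`Cc1nc2c(Cl)cccc2n1-c1ccc(C(=O)NC2CC2)s1`) has not been measured yet. It differs from compound 1 by one swap (chloro in place of methyl on an aromatic carbon): chloro in place of methyl on an aromatic carbon. Among the measured compounds shown here, with compound 1 at 66 mL/min/kg and compound 3 at 68 mL/min/kg as the only numbers to lean on, clearance is expected to stay high in this assay after this swap. The expected 1.1-fold lower number from compound 1 to compound 4 (0.04 log units; within the scatter) is a slight fall that does not go beyond the scatter. For compound 4 the estimated value is 60 mL/min/kg with an expected range from 38 mL/min/kg to 72 mL/min/kg in this estimate.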

Compound 4, clearance: 19 mL/min/kg
Compound 4: middle estimate off by 3.2-fold (0.50 log units), on the high side, and the stated range ends above it.
By their numbers in this assay, from the lowest: compound 4; then compounds 1 and 3 (each within the scatter of the next). At a limit, above all of these: compound 2.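

Chloro in place of methyl on this aromatic carbon, which is ortho to a fused ring, gives a 3.5-fold lower number from compound 1 to compound 4 (0.54 log units; beyond the scatter) in this assay and is the only step measured here between two compounds that differ in one place. The earlier compounds shown here could not show this, as no two of them formed such a pair; now a swap of one heavy atom for another at this place, with the rest of compound 1 unchanged, is seen to move clearance beyond the usual scatter, and compound 4 gives 19 mL/min/kg against the fast clearance of compound 1. These data hold no measured property that explains why the number falls, so the step records what happens and not how it happens.

From the compounds shown here alone, whether fluoro, methoxy, a nitrile or an amine at this same place would lower the number as well, or by a similar amount, remains open. A single step also cannot tell whether chloro in place of methyl would have a similar effect at another place on the ring or on a compound with a different core.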